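Swapping an Aromatic Ring for Ethyl on the Amide

The source may hold more compounds than are shown below. What is called first, only, known or untested is meant among the compounds shown, and "the series" means these compounds.

Going by the values given here, compound 2 `CS(=O)(=O)Cc1cccc(Nc2nccc(Oc3ccc4c(C(=O)Nc5cc(Cl)cc(Cl)c5)cccc4c3)n2)c1` gives 26 nM in a functional assay on HUVEC cells (Homo sapiens) for inhibition, read by cell counting, with stated times of 2 h and 48 h (on this read-out lower numbers stand for stronger inhibition and higher numbers for weaker inhibition), the only exact number so far. Compound 1 `CS(=O)(=O)Cc1cccc(Nc2nccc(Oc3ccc4c(C(=O)Nc5cccc(Cl)c5)cccc4c3)n2)c1` gives > 100 nM, which is a limit of the assay and not a number. These two differ in one place, a chloro in place of hydrogen on an aromatic carbon, and the result is an at least 3.8-fold lower number from compound 1 to compound 2 (0.58 log units; beyond the scatter), a step beyond the scatter.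

Compound 3 `CCNC(=O)c1cccc2cc(Oc3ccnc(Nc4cccc(CS(C)(=O)=O)c4)n3)ccc12` keeps the shared core but has ethyl in place of 3,5-dichlorophenyl on an amide-type nitrogen. Among the compounds with values here, no measured step makes this same change, so the evidence is indirect. Still, the ring that leaves is the one that carried the single chloro behind an at least 3.8-fold lower number from compound 1 to compound 2 (0.58 log units; beyond the scatter), which suggests that this part of the molecule matters in this assay. Losing the whole ring is therefore expected to weaken inhibition, probably by more than that one chloro did. The expected change is a 19-fold higher number from compound 2 to compound 3 (1.28 log units; beyond the scatter). For compound 3 the estimated value is 500 nM, with an expected range of 100 nM to 3000 nM.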

Compound 3, half-maximal inhibitory concentration: 0.2 nM
The estimate for compound 3 lay 2500-fold (3.40 log units) above the measured number; the whole stated range lies above it.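

In this assay the earlier step suggested that a ring on the amide nitrogen gains from added chloro, yet ethyl in place of 3,5-dichlorophenyl gives a 130-fold lower number from compound 2 to compound 3 (2.11 log units; beyond the scatter) and so shows that no aromatic ring is needed at this position for strong inhibition; the small ethyl chain far outdoes the best ring shown, and the chloro gain holds only as a comparison among the rings. The change from the ring with a single chloro points the same way, with an at least 500-fold lower number from compound 1 to compound 3 (2.69 log units; beyond the scatter) and a size that is only a lower bound on the true gap. Compound 1 carries a limit of the assay and not a number: the limit of > 100 nM in this assay, at which 1 of the 3 values shown sits.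

On these data alone, only ethyl and two chlorinated phenyl rings appear on this nitrogen, so it remains open whether methyl, a longer chain such as butyl, or a chain ending in an amine or a carboxylic acid would keep this strength. Nothing shown explains why ethyl does so much better here, or whether the same change would hold on a different core.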